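This account rests on a few compounds, and the source may have more. Where it says the series, first, only, none or still open, it means among the compounds named here.

Measured in an ADME assay on microsomes from liver (Rattus norvegicus) for metabolic stability; on this read-out lower numbers stand for a shorter-lived compound and higher numbers for a longer-lived compound:
- compound 1 `CC(C)C(c1ccc(-c2ccc3cccc(F)c3c2)[nH]c1=O)N1CCCCS1(=O)=O`: 0.07 h
- compound 2 `CC(C)C(c1ccc(-c2ccc3cccc(F)c3c2)[nH]c1=O)N1CCN/C1=N\C#N`: 0.327 h
- compound 3 `CC(C)C(/C=C1/CCNC1=O)c1ccc(-c2ccc3cccc(F)c3c2)[nH]c1=O`: 0.06 h

Compound 3, at 0.06 h, lies within the scatter of compound 1, as the small step shows: a 1.2-fold lower number from compound 1 to compound 3 (0.07 log units; within the scatter). Only compound 2 stands clearly apart: a 5.5-fold lower number from compound 2 to compound 3 (0.74 log units; beyond the scatter).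

Compound 4 `CC(C)C(CC(N)=O)c1ccc(-c2ccc3cccc(F)c3c2)[nH]c1=O` has not yet been measured. Its structure differs by a group of 4 heavy atoms (2 carbon, 1 nitrogen, 1 oxygen; no ring) in place of a group of 7 heavy atoms (5 carbon, 1 nitrogen, 1 oxygen; one five-membered non-aromatic ring with 1 hetero atom), on a saturated chain carbon bound to an aromatic carbon and a saturated chain carbon, so carbamoylmethyl now stands at that place.

Going by the values given here, all the measured steps change the group at this same place. One shows that a change there can move the number beyond the scatter: a 4.7-fold higher number from compound 1 to compound 2 (0.67 log units; beyond the scatter). Another shows that a change there can leave it within the scatter, a 1.2-fold lower number from compound 1 to compound 3 (0.07 log units; within the scatter). Among the compounds with values here, no measured compound carries a group without a ring there, so the evidence is indirect. A small upward move is expected, probably not beyond the scatter. The expected step is a 1.8-fold higher number from compound 3 to compound 4 (0.26 log units; within the scatter). Compound 4 is estimated at 0.11 h, with an expected range from 0.05 h to 0.3 h.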

Compound 4, half-life: < 0.0667 h
Compound 4: a limit, no number (the forecaster's own chance of this, stated with the estimate: 3%); at least 1.6-fold (0.21 log units) between middle value and limit.
By their numbers in this assay, from the lowest: compounds 3 and 1 (each within the scatter of the next); then compound 2.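

Going by these compounds alone, the step of an at least 4.9-fold lower number from compound 2 to compound 4 (0.69 log units; beyond the scatter) shows that carbamoylmethyl, the first group without a ring at this place, does not hold the number reached with the group of compound 2. The step of an at least 1.0-fold lower number from compound 1 to compound 4 (0.02 log units; that floor lies within the scatter) has a floor within the scatter and so separates nothing, and the step from compound 3 to compound 4 cannot be read. Compound 4 stands as a limit and not a number in this assay and this group without a ring gives nothing more exact: the limit of < 0.0667 h in this assay, at which 1 of the 4 values shown sits.

On these data alone, how far below its limit compound 4 lies stays open, and with it any order among compound 1, compound 3 and compound 4. Also open, as far as these compounds go, is whether another group without a ring at this place, such as an amine, a carboxylic acid or a longer chain, would stay with carbamoylmethyl or come nearer to compound 2.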